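The source may report more compounds than this note shows. Statements on the series, on what has been measured and on what is new or still open speak of the compounds shown alone.

Compound 1 `Cc1cccc(NC(=O)COc2ccc(/C=C3\SC(=O)NC3=O)cc2)n1`: in a functional assay on KB cells (Homo sapiens) for inhibition (on this read-out higher numbers stand for weaker inhibition of growth and lower numbers for stronger inhibition of growth), compound 1 gives 75000 nM.
Compound 2 `O=C(COc1ccc(/C=C2\SC(=O)NC2=O)cc1)Nc1ccc(Cl)cc1`: in this assay compound 2 gives 50300 nM.
Compound 3 `O=C(COc1ccc(/C=C2\SC(=O)NC2=O)cc1)Nc1ccc(F)cc1F`: in this assay compound 3 gives > 100000 nM, which is a limit of the assay and not a number.

Compound 3 therefore sits at the upper boundary of what this assay reports, the same boundary described by the limit of > 100000 nM in this assay, at which 1 of the 3 values shown sits. None of the three compounds separates clearly from the others: the change a 1.5-fold lower number from compound 1 to compound 2 (0.17 log units; within the scatter) is within the scatter, and both an at least 1.3-fold higher number from compound 1 to compound 3 (0.12 log units; that floor lies within the scatter) and an at least 1.9-fold higher number from compound 2 to compound 3 (0.29 log units; that floor lies within the scatter) have floors that also lie within the scatter. Swapping the group on the amide-type nitrogen has so far made no difference that can be trusted.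

Compound 4 `O=C(COc1ccc(/C=C2\SC(=O)NC2=O)cc1)Nc1c(Cl)cccc1Cl` carries the next such swap: 2,6-dichlorophenyl in place of 2,4-difluorophenyl on an amide-type nitrogen. Since every earlier exchange at this position stayed within the scatter, the step of a number no higher from compound 3 to compound 4 (the limit leaves the size open) is expected to show no change beyond the scatter either. Compound 4 is thus expected to give about 100000 nM in this assay, somewhere between 40000 nM and 300000 nM, and it may well again be reported only as a limit.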

Compound 4, concentration for 50% growth inhibition: > 100000 nM
Compound 4 gave a limit, no number; the forecaster's own chance of this, stated with the estimate: 55%; the middle value sits exactly at the limit.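

Compound 3 and compound 4 both end at a limit of the assay, so the step between them cannot be read. Against the other two compounds, an at least 1.9-fold higher number from compound 2 to compound 4 (0.29 log units; that floor lies within the scatter) and an at least 1.3-fold higher number from compound 1 to compound 4 (0.12 log units; that floor lies within the scatter) have floors that lie within the scatter, so no exchange at this position yet separates one compound clearly from another. What is new is that a second group on the amide-type nitrogen, now with chlorine in place of fluorine, ends at the upper boundary of the assay: the limit of > 100000 nM in this assay, at which 2 of the 4 values shown sit.

On these data alone, whether any group at this position can give clearly stronger inhibition of growth remains open, and so does whether the two compounds at the limit differ at all. A phenyl ring carrying an amine or a carboxylic acid in place of these halogens would put that question to a different kind of group.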